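The source may report more compounds than this note shows. Statements on the series, on what has been measured and on what is new or still open speak of the compounds shown alone.

Compound 1, `CC(C)[C@H](NC(=O)COc1cccc2ccccc12)C(=O)N[C@@H](CC(=O)O)C(=O)COc1ccc(C(F)(F)F)cc1` — in a functional assay on Jurkat cells (Homo sapiens) (a lower number here means a stronger inhibitor, a higher number a weaker inhibitor), compound 1 gives > 100000 nM, which is a limit of the assay and not a number.
Compound 2, `CC(=O)Nc1cccc(OCC(=O)[C@H](CC(=O)O)NC(=O)[C@@H](NC(=O)COc2cccc3ccccc23)C(C)C)c1` — in this assay compound 2 gives > 100000 nM, again a limit of the assay.
Compound 3, `CC(C)[C@H](NC(=O)COc1cccc2ccccc12)C(=O)N[C@@H](CC(=O)O)C(=O)COc1cccc(F)c1` — in this assay compound 3 gives > 100000 nM, once more a limit of the assay.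

Compound 1 therefore stands only at a limit in this assay, and the two other values are limits as well; all three sit at the limit of > 100000 nM in this assay, at which 3 of the 3 values shown sit. The account follows the change from compound 1 to compound 4, `CC(C)[C@H](NC(=O)COc1cccc2ccccc12)C(=O)N[C@@H](CC(=O)O)C(=O)COc1cc(F)cc(F)c1`, in which (3,5-difluorophenyl in place of 4-(trifluoromethyl)phenyl on an oxygen on a saturated carbon). The measured steps that touch the same position are a step that the two limits leave unreadable from compound 1 to compound 2 and a step that the two limits leave unreadable from compound 1 to compound 3; both are unreadable, since their two ends are limits, as is a step that the two limits leave unreadable from compound 2 to compound 3. Among the compounds with values here, no measured step on this oxygen on a saturated carbon has moved a compound off the limit, so no step beyond the scatter is expected in this assay for compound 4. The estimate for compound 4 is therefore itself most likely a limit: compound 4 is expected at 150000 nM, within 30000 nM to 1000000 nM, and the step from compound 1 is expected to be a step that the limit leaves unreadable from compound 1 to compound 4.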

Compound 4, half-maximal inhibitory concentration: > 100000 nM
Compound 4: no number, only a limit (the forecaster's own chance of this, stated with the estimate: 85%); the middle value does not contradict the limit.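

In this assay, within the data shown here, compound 4 gives > 100000 nM, a limit of the assay, so no step to it from compound 1, compound 2 or compound 3 can be read. The compounds shown leave open whether any group on this oxygen would move a value off the shared limit: the limit of > 100000 nM in this assay, at which 4 of the 4 values shown sit.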